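Aryl substituent variation on the fused core: compound 4

The source may hold more compounds than are shown below. What is called first, only, known or untested is meant among the compounds shown, and "the series" means these compounds.

Compound 1, `Cc1nc2c3ccccc3ccc2c2nc3c(ccc4ccccc43)c(-c3ccccc3Cl)c12`: 48200 nM
Compound 2, `Cc1nc2c3ccccc3ccc2c2nc3c(ccc4ccccc43)c(-c3ccccc3S)c12`: 1420 nM
Compound 3, `Cc1ccc(-c2c3ccc4ccccc4c3nc3c2c(C)nc2c4ccccc4ccc32)cc1`: 67000 nM

All values come from a functional assay on HCT-116 cells (Homo sapiens) for cytotoxicity, read by MTT assay, with a stated time of 48 h; a higher number here means a weaker inhibitor, a lower number a stronger inhibitor. Compound 3 gives the highest number of the three; the gap to compound 1 is within the scatter, a 1.4-fold higher number from compound 1 to compound 3 (0.14 log units; within the scatter), whereas the gap to compound 2 is large, a 47-fold higher number from compound 2 to compound 3 (1.67 log units; beyond the scatter). Compound 4, `Cc1nc2c3ccccc3ccc2c2nc3c(ccc4ccccc43)c(-c3cc([N+](=O)[O-])ccc3N)c12`, differs from compound 3 in one place: 2-amino-5-nitrophenyl in place of 4-methylphenyl on an aromatic carbon. Within the data shown here, the steps that bear on this are those at the same aromatic carbon, a 34-fold lower number from compound 1 to compound 2 (1.53 log units; beyond the scatter) and a 47-fold higher number from compound 2 to compound 3 (1.67 log units; beyond the scatter), both large and both favouring the 2-sulfanylphenyl of compound 2 over the other aryl groups. For compound 4 a step toward a lower number is therefore expected, of uncertain size, an 8.4-fold lower number from compound 3 to compound 4 (0.92 log units; beyond the scatter). Compound 4 is estimated at 8000 nM, range 1500 nM to 40000 nM.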

Compound 4, half-maximal inhibitory concentration: 6010 nM
For compound 4 the middle estimate is 1.3-fold (0.12 log units) above the measured one, and the stated range covers the measured number.
By their numbers in this assay, from the lowest: compound 2; then compound 4; then compounds 1 and 3 (each within the scatter of the next).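

At this aromatic carbon, opposite the ring nitrogen, a low number is not confined to the 2-sulfanylphenyl of compound 2: 2-amino-5-nitrophenyl gives an 11-fold lower number from compound 3 to compound 4 (1.05 log units; beyond the scatter) and an 8.0-fold lower number from compound 1 to compound 4 (0.90 log units; beyond the scatter). The 2-sulfanylphenyl still keeps the lower number, with a 4.2-fold higher number from compound 2 to compound 4 (0.63 log units; beyond the scatter). No measurement at hand gives a cause for these steps.

From the compounds shown here alone, the amino and nitro groups enter together, so the share of each in the step stays open. Also open, going by these compounds, is where a 2-aminophenyl without the nitro group or a 2-hydroxyphenyl would fall.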